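The source may hold more compounds than are shown below. What is called first, only, known or untested is meant among the compounds shown, and "the series" means these compounds.

Measured so far in a functional assay on MCF7 cells (Homo sapiens) for antiproliferative activity, read by sulforhodamine B assay, with a stated time of 48 h; a lower number here means a stronger inhibitor, a higher number a weaker inhibitor:
compound 1 `CCCN1CCN(c2ccc(S(=O)(=O)Oc3ccccc3CC)cc2)C1=O`: 2300 nM
compound 2 `CCCN1CCN(c2ccc(S(=O)(=O)Oc3cc(Cl)c(Cl)cc3Cl)cc2)C1=O`: 13000 nM
compound 3 `CCCN1CCN(c2ccc(S(=O)(=O)Oc3c(Cl)cc(Cl)cc3Cl)cc2)C1=O`: > 100000 nM (a limit of the assay, not a number)

Compound 3 is known only through a limit, and its place in the series is the limit of > 100000 nM in this assay, at which 1 of the 3 values shown sits, with no number behind it. Its two measured steps are an at least 43-fold higher number from compound 1 to compound 3 (1.63 log units; beyond the scatter) and an at least 7.6-fold higher number from compound 2 to compound 3 (0.88 log units; beyond the scatter) and they put it at the weak end of these three compounds.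

Compound 4 `CCCN1CCN(c2ccc(S(=O)(=O)Oc3cccc(OC)c3)cc2)C1=O` is not yet measured. It has 3-methoxyphenyl in place of 2,4,6-trichlorophenyl on an oxygen whose other neighbour is the sulfonyl sulfur (3-methoxyphenyl in place of 2,4,6-trichlorophenyl on an oxygen).

Going by the values given here, no measured compound carries 3-methoxyphenyl, so the closest guides are the two steps that end on compound 3, read backwards. Both change the same position, and the larger one starts from a compound with a single substituted phenyl, where compound 1 gives 2300 nM in the same assay. Among the compounds with values here, the smaller spread among the measured numbers is a 5.7-fold higher number from compound 1 to compound 2 (0.75 log units; beyond the scatter) and it marks how far a different phenyl has moved the value so far.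

A large step toward a lower number is therefore expected, estimated as an at least 28-fold lower number from compound 3 to compound 4 (1.45 log units; beyond the scatter) in this assay on this reading. Compound 4 is estimated at 3500 nM within an expected range of 600 nM to 20000 nM.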

Compound 4, half-maximal inhibitory concentration: 6300 nM
The estimate for compound 4 lay 1.8-fold (0.26 log units) below the measured number, and the stated range covers the measured number.
By their numbers in this assay, from the lowest: compound 1; then compound 4; then compound 2. At a limit, above all of these: compound 3.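

In this assay, 3-methoxyphenyl on the oxygen whose other neighbour is the sulfonyl sulfur gives a large change from 2,4,6-trichlorophenyl: an at least 15-fold lower number from compound 3 to compound 4 (1.20 log units; beyond the scatter). Compound 4 also settles between the two other measured compounds, with a 2.1-fold lower number from compound 2 to compound 4 (0.31 log units; beyond the scatter) and a 2.7-fold higher number from compound 1 to compound 4 (0.44 log units; beyond the scatter), both modest but beyond the scatter, so three different groups at this place now give measured values, including one with a methoxy group and no chlorine. Compound 3 remains the only one of the four without a number, and its step is a bound and not a size, as its value is a limit of the assay: the limit of > 100000 nM in this assay, at which 1 of the 4 values shown sits.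

The compounds shown leave open what the methoxy group itself contributes, as an unsubstituted phenyl or a 2-methoxyphenyl would show, and whether an amine or a carboxylic acid on this ring would keep a measurable value. Also open, as far as these compounds go, is what a longer chain in place of the propyl group on the shared core would do to the values seen at this place.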